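Replacing an amine with an ether on the shared core

A few compounds are considered here, and "the series" means these few. Any claim that something is new, unique, unknown or untested is made for them only; others in the source may bear on it.

Of the compounds shown here, three with a shared core have been measured in an in vitro assay on 293-EBNA cells for binding affinity to corticotropin-releasing factor receptor 1 (Homo sapiens); a higher number here means a weaker inhibitor, a lower number a stronger inhibitor. Compound 1 `CCCCN(CC)c1nc(C)nc2c1nnn2-c1c(C)cc(C)nc1C` gives 65 nM. Compound 3 `CCN(CC)c1nc(C)nc2c1ncn2-c1ccc(C(C)C)cc1Br` gives 12.4 nM. Compound 2 `COCC(C)(C)Nc1nc(C)nc2c1nnn2-c1ccc(C(C)C)cc1Br` gives 195 nM, which is the highest of the three numbers, so compound 2 is the weakest inhibitor among them. Compound 2 sits nearest to compound 1 and furthest from compound 3, and both gaps lie beyond the usual scatter of repeated measurements.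

Compound 4 `CCOCC(COCC)Oc1nc(C)nc2c1nnn2-c1ccc(C(C)C)cc1Br` is compound 2 with one change: a group of 10 heavy atoms (7 carbon, 3 oxygen; no ring) in place of a group of 7 heavy atoms (5 carbon, 1 nitrogen, 1 oxygen; no ring), on an aromatic carbon. The group that leaves is the (1-(methoxymethyl)-1-methylethyl)amino group; the group that enters has no common name and sits on the same aromatic carbon, next to the ring nitrogen and meta to a methyl group. Among the measured compounds shown here, no pair of measured compounds differs in exactly this way, so no measured step guides the expectation directly.

The amine that leaves carried one hydrogen-bond donor, and the group that enters carries none. Without a measured comparison, a modest change in either direction, or none beyond the scatter, is expected, and the estimated step is a 1.3-fold higher number from compound 2 to compound 4 (0.11 log units; within the scatter). On that basis compound 4 is expected to give about 250 nM in this assay, with a likely range from 60 nM to 1000 nM.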

Compound 4, inhibition constant: 39.7 nM
The estimate for compound 4 lay 6.3-fold (0.80 log units) above the measured number; the measured number lies below the stated range.
By their numbers in this assay, from the lowest: compound 3; then compounds 4 and 1 (each within the scatter of the next); then compound 2.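

In this assay, the aromatic carbon of the shared core that holds the (1-(methoxymethyl)-1-methylethyl)amino group in compound 2 accepts a quite different, larger chain, and the swap gives a 4.9-fold lower number from compound 2 to compound 4 (0.69 log units; beyond the scatter). The group that leaves has a hydrogen-bond donor and the group that enters has none, so for this pair, a donor on this side chain is not needed for the stronger result. The swap alters the atom attached to the ring, the size of the group and its donor and acceptor counts all at once, and nothing available explains the gain or assigns it to any one of these changes.

From the compounds shown here alone, it remains open whether the gain follows the oxygen attached to the ring or the rest of the chain, which an amine carrying the same branched chain would help to separate. A plain methoxy group on the same aromatic carbon would show how much of the chain is needed to keep a number as low as that of compound 4, 39.7 nM.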